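The source may report more compounds than this note shows. Statements on the series, on what has been measured and on what is new or still open speak of the compounds shown alone.

Three compounds share one core and differ only in the group on the fused carbocyclic ring. In a functional assay on A-375 cells (Homo sapiens) for antiproliferative activity, read by MTT assay, with a stated time of 24 h, tested at 0.14 ug/mL (a lower number here means a weaker effect, a higher number a stronger effect of the compound at the concentration tested), compound 1 `Cc1ccc2nc(C(=O)Nc3c(F)cc(-c4cccc(F)c4)cc3F)c(C)c(C(=O)O)c2c1` gives 0.98%, compound 2 `CCc1ccc2nc(C(=O)Nc3c(F)cc(-c4cccc(F)c4)cc3F)c(C)c(C(=O)O)c2c1` gives 2.45%, and compound 3 `COc1ccc2nc(C(=O)Nc3c(F)cc(-c4cccc(F)c4)cc3F)c(C)c(C(=O)O)c2c1` gives 2.06%. On these numbers compound 3 sits second highest of the three, but the gaps to both neighbours lie within the scatter: a number 0.4 percentage points lower from compound 2 to compound 3 (within the scatter) and a number 1.1 percentage points higher from compound 1 to compound 3 (within the scatter). The unmeasured compound 4 `Cc1c(C(=O)Nc2c(F)cc(-c3cccc(F)c3)cc2F)nc2ccc(C(F)(F)F)cc2c1C(=O)O` is reached from compound 3 by a single change, (trifluoromethyl in place of methoxy on an aromatic carbon). The measured steps that bear on this are the ones that vary the group at this same position, a number 1.5 percentage points higher from compound 1 to compound 2 (within the scatter) and a number 1.1 percentage points higher from compound 1 to compound 3 (within the scatter), together with a number 0.4 percentage points lower from compound 2 to compound 3 (within the scatter); none of them moved the read-out beyond the scatter. Compound 4 is therefore expected to show a number 0.4 percentage points higher from compound 3 to compound 4 (within the scatter), that is, no step beyond the scatter. In this assay compound 4 is estimated at 2.5%, with a range from 0% to 9%.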

Compound 4, a percentage reported as inhibition, at one concentration (the size of the read-out at that concentration, not a potency): 2.56%
For compound 4 the middle estimate is 0.1 percentage points below the measured one; low and high end bracket the measured number.
By their numbers in this assay, from the lowest: compounds 1, 3, 2 and 4 (each within the scatter of the next).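

The change from methoxy to trifluoromethyl, which brings in fluorine and removes the oxygen that counted as a hydrogen-bond acceptor, leaves the read-out in this assay within the scatter (a number 0.5 percentage points higher from compound 3 to compound 4 (within the scatter)). Trifluoromethyl also shows no step beyond the scatter against the two alkyl groups (a number 0.1 percentage points higher from compound 2 to compound 4 (within the scatter); a number 1.6 percentage points higher from compound 1 to compound 4 (within the scatter)), so methyl, ethyl, methoxy and trifluoromethyl at this position cannot be told apart in this assay. No available evidence bears on this result.

Whether any group at this position can move the read-out beyond the scatter stays open, since an amine, a hydroxyl or a longer chain such as butyl does not appear among these compounds. On these data alone, a single concentration also gives no potency, so any differences that might show across a range of concentrations remain unknown.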